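Pyridin-3-yl for cyclobutyl: a small shift expected

A few compounds are considered here, and "the series" means these few. Any claim that something is new, unique, unknown or untested is made for them only; others in the source may bear on it.

Compound 3 `O=c1cc(C2CCC2)oc2ccc(OCCCCCCN3CCCCC3)cc12` gives 34 nM in an assay on isolated protein (Cavia porcellus) with Sigma non-opioid intracellular receptor 1 (Homo sapiens) as the target, read by radioligand binding (on this read-out lower numbers stand for stronger inhibition and higher numbers for weaker inhibition), and stands lowest of the three numbers measured. Its nearest neighbour is compound 1 `O=c1cc(-c2ccccc2)oc2ccc(OCCCCCCN3CCCCC3)cc12`, which gives 54 nM in this assay, and a 1.6-fold lower number from compound 1 to compound 3 (0.20 log units; within the scatter) lies within the scatter. Compound 2 `O=c1cc(-c2ccccc2)oc2ccc(OCCCCCCN3CCNCC3c3ncccn3)cc12` gives 14200 nM in this assay, and a 260-fold higher number from compound 1 to compound 2 (2.42 log units; beyond the scatter) is a large step at a different place, so it does not bear on the change considered here. Compound 4 `O=c1cc(-c2cccnc2)oc2ccc(OCCCCCCN3CCCCC3)cc12` carries pyridin-3-yl in place of cyclobutyl on an aromatic carbon. Within the data shown here, the only measured step at this position, a 1.6-fold lower number from compound 1 to compound 3 (0.20 log units; within the scatter), stayed within the scatter, so no step beyond the scatter is expected for compound 4 in this assay, a 1.8-fold higher number from compound 3 to compound 4 (0.25 log units; within the scatter). Compound 4 is therefore estimated at 60 nM, with a range from 20 nM to 200 nM.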

Compound 4, half-maximal inhibitory concentration: 192 nM
Beside the measured number, compound 4's estimate is 3.2-fold (0.51 log units) below it; the measured number falls inside the stated range.
By their numbers in this assay, from the lowest: compounds 3 and 1 (each within the scatter of the next); then compound 4; then compound 2.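

At the position next to the ring oxygen, the number does respond to the group carried: pyridin-3-yl gives a 5.6-fold higher number from compound 3 to compound 4 (0.75 log units; beyond the scatter) in this assay. The same group also gives a 3.6-fold higher number from compound 1 to compound 4 (0.55 log units; beyond the scatter), so it stands apart from both phenyl and cyclobutyl, which lie within the scatter of each other. No evidence at hand accounts for this shift.

The compounds shown leave open whether the ring nitrogen's place matters, since how pyridin-2-yl or pyridin-4-yl would read here remains unknown. As far as these compounds go, how a phenyl bearing an amine would read also remains open.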